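Methylsulfanyl in Place of Hydrogen: Electroshock Read-out

The source may report more compounds than this note shows. Statements on the series, on what has been measured and on what is new or still open speak of the compounds shown alone.

Measured so far in a functional assay on the whole organism for inhibition, with Rattus norvegicus as the target, in the maximal electroshock model, at a dose of 25 mg/kg by the intraperitoneal route; on this read-out lower numbers stand for less inhibition and higher numbers for more inhibition at the one dose given (going by the name of the read-out):
compound 1 `c1ccc(Cn2cnc3cncnc32)cc1` gives 33%
compound 2 `c1ccc(Cn2cnc3c(N4CCC4)ncnc32)cc1` gives 17%
compound 3 `CN(C=O)c1ncnc2c1ncn2Cc1ccccc1` gives 0%

Compound 1 stands highest of the three numbers in this assay, and both of its neighbours lie beyond the scatter below it. Compound 2 carries azetidin-1-yl in place of hydrogen on an aromatic carbon, and the step is a number 16 percentage points lower from compound 1 to compound 2 (beyond the scatter). Compound 3 carries formyl(methyl)amino in place of hydrogen at the same carbon, and the step is a number 33 percentage points lower from compound 1 to compound 3 (beyond the scatter). Between the two substituted compounds the step is a number 17 percentage points lower from compound 2 to compound 3 (beyond the scatter).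

Compound 4 `CSc1ncnc2c1ncn2Cc1ccccc1` differs from compound 1 in this way: methylsulfanyl in place of hydrogen on an aromatic carbon. The two measured steps from compound 1 bear on it, since both replace hydrogen at this aromatic carbon, and both lowered the read-out, one modestly and one largely. Methylsulfanyl is smaller than either of those entering groups and brings no ring, so a lowering is expected that stays on the modest side. Compound 4 is therefore estimated to give 20%, with a range from 5% to 38%. The estimated step is a number 13 percentage points lower from compound 1 to compound 4 (beyond the scatter).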

Compound 4, a percentage reported as inhibition, in the whole organism at one dose (the size of the read-out at that dose, not a potency): 30%
Estimate against measurement, compound 4: 10 percentage points below; the range from low to high includes it.
By their numbers in this assay, from the lowest: compound 3; then compound 2; then compounds 4 and 1 (each within the scatter of the next).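

In this assay, methylsulfanyl on this aromatic carbon, next to the ring nitrogen, gives a number 3 percentage points lower from compound 1 to compound 4 (within the scatter) and so is the one entering group shown whose step from hydrogen stays within the scatter. Substitution at this carbon therefore does not lower the read-out in every case, and the lowering seen with azetidin-1-yl and formyl(methyl)amino goes with those particular groups, not with the loss of hydrogen alone. The entering group makes a clear difference here, as the change of azetidin-1-yl to methylsulfanyl gives a number 13 percentage points higher from compound 2 to compound 4 (beyond the scatter) and the change of formyl(methyl)amino to methylsulfanyl gives a number 30 percentage points higher from compound 3 to compound 4 (beyond the scatter) in this assay; no measurement is available that would explain these differences.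

The compounds shown leave open whether the sulfur atom matters, which methoxy or a longer chain such as ethylsulfanyl would test at the same carbon. They also leave open whether an open-chain amine such as dimethylamino would follow methylsulfanyl or azetidin-1-yl, and whether any group at this carbon could lift the read-out clearly above that of compound 1 at the one dose given.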